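Reversed amide at the biaryl terminus of the isoxazole series

The source may report more compounds than this note shows. Statements on the series, on what has been measured and on what is new or still open speak of the compounds shown alone.

Compound 1 `O=C(O)c1ccc2noc(-c3ccc(-c4cccnc4)cc3)c2c1` carries a pyridin-3-yl on the outer ring of the shared core and in an assay for inhibition of inositol hexakisphosphate kinase 3 (Homo sapiens), read by colorimetric assay, coupled enzyme assay and malachite green, with a stated time of 120 min, in the presence of a further agent that is not named here (a lower number here means a stronger inhibitor, a higher number a weaker inhibitor), gives 610 nM. Among the measured compounds shown here, compound 2 `CC(C)C(=O)Nc1ccc(-c2onc3ccc(C(=O)O)cc23)cc1` replaces that group with (isopropylcarbonyl)amino and in this assay gives 210 nM; it stands as the lower of the two numbers, with compound 1 as its only neighbour, the step of a 2.9-fold lower number from compound 1 to compound 2 (0.46 log units; beyond the scatter) being modest but beyond the scatter.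

Compound 3 `CC(C)NC(=O)c1ccc(-c2onc3ccc(C(=O)O)cc23)cc1` is the next member, differing from compound 2 only in that (isopropylcarbamoyl in place of (isopropylcarbonyl)amino on an aromatic carbon). For the measured compounds named here, no measured pair reverses an amide, so the one step on record bears only loosely: it shows that an amide of this size at that position is tolerated and somewhat favoured over pyridin-3-yl. The reversal keeps the same atoms, the same donor and acceptor count and the same bond pattern apart from the connection, so a change within or near the scatter is expected, in either direction.

For compound 3 the estimate in this assay is 260 nM, with a range of 100 nM to 700 nM, an expected step of a 1.2-fold higher number from compound 2 to compound 3 (0.09 log units; within the scatter).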

Compound 3, half-maximal inhibitory concentration: 340 nM
Compound 3: the middle estimate sits 1.3-fold (0.12 log units) below what was measured; the measured number falls inside the stated range.
By their numbers in this assay, from the lowest: compounds 2, 3 and 1 (each within the scatter of the next, the first and the last beyond it).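

Swapping the amide's orientation at this position, on an aromatic carbon para to a large group, gives a 1.6-fold higher number from compound 2 to compound 3 (0.21 log units; within the scatter) in this assay, so the two connections, built from the same atoms, cannot be told apart on this measurement. The comparison with the pyridin-3-yl group reads differently: a 1.8-fold lower number from compound 1 to compound 3 (0.25 log units; within the scatter) also lies within the scatter, whereas the step from compound 1 to compound 2 lies beyond it. Compound 3 therefore sits within the scatter of both neighbours, and the clear separation from compound 1 holds for the (isopropylcarbonyl)amino group alone, not for amides at this position in general.

Still open, from the compounds shown here alone, is whether a cyclopropyl ring or a longer chain on the amide nitrogen, or a simple amine in place of the whole amide, would separate from these three compounds in this assay by more than the scatter. Among the compounds shown here, no supporting measurement is available to explain why the two amide orientations read alike or why only one separates from compound 1.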